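Fluoro for Methoxymethyl on the Pyrimidine of Compound 3

The compounds below may be only part of what the source reports. "The series", "measured", "known", "first", "only" and "open" are said of these compounds alone.

Compound 1 `CCc1cnc(N2CCC([C@H]3C[C@H]3COCc3ccc(S(C)(=O)=O)cn3)CC2)nc1`: 2.5 nM
Compound 2 `CCOc1cnc(N2CCC([C@H]3C[C@H]3COCc3ccc(S(C)(=O)=O)c(F)c3)CC2)nc1`: 2.3 nM
Compound 3 `COCc1cnc(N2CCC([C@H]3C[C@H]3COCc3ccc(S(C)(=O)=O)c(F)c3)CC2)nc1`: 5.2 nM

In a functional assay on isolated protein for agonist activity at Glucose-dependent insulinotropic receptor (Mus musculus), read by cAMP accumulation (on this read-out higher numbers stand for an effect only at larger amounts of compound and lower numbers for an effect already at smaller amounts), compound 3 gives the highest of the three numbers shown. Its nearest neighbour is compound 1, and the step from compound 2 to compound 3 is a 2.3-fold higher number from compound 2 to compound 3 (0.35 log units; beyond the scatter), a modest move to a weaker effect. Compound 4 `CS(=O)(=O)c1ccc(COC[C@@H]2C[C@@H]2C2CCN(c3ncc(F)cn3)CC2)cc1F` carries a small change: fluoro in place of methoxymethyl on an aromatic carbon. Going by the values given here, no measured pair shows this exact exchange. Among the compounds with values here, the only step at the same position, from compound 2 to compound 3, was modest, and compounds 1 and 2, with ethyl and ethoxy at that position, both sit close together at low numbers. A small group at this carbon has so far gone with the lower numbers, so compound 4 is expected to move back toward those, by about a 1.5-fold lower number from compound 3 to compound 4 (0.17 log units; within the scatter) in this assay. The estimate for compound 4 is therefore 3.5 nM, with a range from 1.2 nM to 10 nM.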

Compound 4, half-maximal effective concentration: 4.5 nM
Beside the measured number, compound 4's estimate is 1.3-fold (0.11 log units) below it; the range from low to high includes it.
By their numbers in this assay, from the lowest: compounds 2, 1, 4 and 3 (each within the scatter of the next, the first and the last beyond it).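

In this assay the change from 5-(methoxymethyl)pyrimidin-2-yl to 5-fluoropyrimidin-2-yl gives a 1.2-fold lower number from compound 3 to compound 4 (0.06 log units; within the scatter), so a single fluorine can stand where 3 heavy atoms stood without a step beyond the scatter. The exchange of ethoxy for fluoro gives a 2.0-fold higher number from compound 2 to compound 4 (0.29 log units; within the scatter), which also stays within the scatter. Compound 4 therefore lies within the scatter of both compound 2 and compound 3, even though the earlier step between those two, a 2.3-fold higher number from compound 2 to compound 3 (0.35 log units; beyond the scatter), lies beyond it, so the position tolerates a lone halogen as well as either of these oxygen-bearing groups.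

Going by these compounds, whether chloro, a nitrile, an amine or a longer chain such as propoxy at this carbon would keep the number in the same range remains open. Nothing shown here explains why the number changes so little across these groups.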